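Swapping the aryl group on the ring nitrogen

This account rests on a few compounds, and the source may have more. Where it says the series, first, only, none or still open, it means among the compounds named here.

Measured so far:
compound 1, `Nc1scc(CN2CCN(c3ccc(Cl)cc3F)CC2)c1C(=O)c1ccc(Cl)cc1`, gives -57%
compound 2, `COc1ccc(N2CCN(Cc3csc(N)c3C(=O)c3ccc(Cl)cc3)CC2)cc1`, gives -15%
compound 3, `Nc1scc(CN2CCN(c3ccc(Cl)c(C(F)(F)F)c3)CC2)c1C(=O)c1ccc(Cl)cc1`, gives -47%

In a functional assay on CHO cells with adenosine receptor A1 (Homo sapiens) as the target, read by cAMP accumulation and immunoassay, with a stated time of 6 min, tested at 1 uM (a higher number here means a weaker effect of the compound at the concentration tested, a lower number a stronger effect), compound 1 stands lowest of the three numbers; compound 3 sits close to it, within the scatter, while compound 2 lies well above it. Compound 4, `Nc1scc(CN2CCN(c3ccc(OC(F)(F)F)cc3)CC2)c1C(=O)c1ccc(Cl)cc1`, differs from compound 1 in one place: 4-(trifluoromethoxy)phenyl in place of 4-chloro-2-fluorophenyl on an amine nitrogen in a ring.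

Two measured steps change the same group on the same nitrogen. The step of a number 42 percentage points higher from compound 1 to compound 2 (beyond the scatter) brought in a 4-methoxyphenyl, which like the entering 4-(trifluoromethoxy)phenyl carries one hydrogen-bond acceptor. The step of a number 10 percentage points higher from compound 1 to compound 3 (within the scatter), bringing in a group with no acceptor, stayed within the scatter. A rise beyond the scatter is therefore expected for compound 4, though not as large as in compound 2. Compound 4 is estimated at -32%, between -55% and -8%, an expected step of a number 25 percentage points higher from compound 1 to compound 4 (beyond the scatter).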

Compound 4, a percentage reported as activity, at one concentration (the size of the read-out at that concentration, not a potency): -51%
The estimate for compound 4 lay 19 percentage points above the measured number, and the stated range covers the measured number.
By their numbers in this assay, from the lowest: compounds 1, 4 and 3 (each within the scatter of the next); then compound 2.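

A hydrogen-bond acceptor on this aryl group does not by itself raise the number: 4-(trifluoromethoxy)phenyl gives a number 6 percentage points higher from compound 1 to compound 4 (within the scatter) and a number 4 percentage points lower from compound 3 to compound 4 (within the scatter). The change at the oxygen alone, trifluoromethyl in place of methyl, gives a number 36 percentage points lower from compound 2 to compound 4 (beyond the scatter), which leaves compound 2, with its 4-methoxyphenyl, as the only one of the four apart from the rest. Nothing measured here explains this difference. Going by these compounds, whether an ethoxy or a dimethylamino group on the phenyl ring would behave like methoxy or like trifluoromethoxy stays open.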